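The compounds below may be only part of what the source reports. "The series", "measured", "known", "first", "only" and "open" are said of these compounds alone.

In a functional assay on PC-3 cells (Homo sapiens) for antiproliferative activity, read by MTT assay, with a stated time of 48 h (a lower number here means a stronger inhibitor, a higher number a weaker inhibitor), compound 1 (`COc1ccc(CN(C(=O)CSc2ccccn2)c2cc(OC)c(OC)c(OC)c2)cc1`) gives 7510 nM and compound 2 (`COc1ccc(CN(C(=O)CSc2nnnn2C)c2cc(OC)c(OC)c(OC)c2)cc1`) gives 10500 nM. These two values lie within the usual scatter of each other, so compound 2 cannot be ranked against compound 1. Compound 3 (`COc1ccc(CN(C(=O)CSc2nncs2)c2cc(OC)c(OC)c(OC)c2)cc1`) keeps the shared core and differs only in the ring on the sulfur: 1,3,4-thiadiazol-2-yl in place of 1-methyl-1H-tetrazol-5-yl on a sulfur. Going by the values given here, the one measured step that bears on this change is a 1.4-fold higher number from compound 1 to compound 2 (0.15 log units; within the scatter), which put 1-methyl-1H-tetrazol-5-yl in place of pyridin-2-yl on that same sulfur. That exchange of one ring for another stayed within the scatter, so no step beyond the scatter is expected in this assay here, and no direction can be argued. A single step is thin evidence, so the range is kept wide. The expected step is a 1.2-fold lower number from compound 2 to compound 3 (0.09 log units; within the scatter). The estimate for compound 3 is 8500 nM, with an expected range of 3500 nM to 20000 nM.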

Compound 3, half-maximal inhibitory concentration: 5530 nM
The estimate for compound 3 lay 1.5-fold (0.19 log units) above the measured number; low and high end bracket the measured number.
By their numbers in this assay, from the lowest: compounds 3, 1 and 2 (each within the scatter of the next).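

Placing 1,3,4-thiadiazol-2-yl on the sulfur gives a 1.9-fold lower number from compound 2 to compound 3 (0.28 log units; within the scatter) and a 1.4-fold lower number from compound 1 to compound 3 (0.13 log units; within the scatter), so a third ring, this one carrying a ring sulfur and no methyl group, also fails to separate from the others in this assay. Going by these compounds alone, the earlier pair offered only one exchange of rings, whereas all three rings can now be compared with one another, and none of the three steps among them leaves the scatter. Nothing available explains why these exchanges stay so close, and the small differences give no basis for preferring one ring.

From the compounds shown here alone, all three compounds carry an aromatic ring on this sulfur, so it remains open whether an amine, a carboxylic acid or a longer chain there would shift the number beyond the scatter. Going by these compounds, the effect of changes elsewhere on the shared core also remains open.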